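Replacing Diethoxymethyl with 1,3-Dioxolan-2-yl: Tolerated Concentrations

The source may report more compounds than this note shows. Statements on the series, on what has been measured and on what is new or still open speak of the compounds shown alone.

The measured compounds:
compound 1 `CCOC(OCC)c1cn(C2C[C@H](OC(C)=O)[C@@H](COC(C)=O)O2)c(=O)[nH]c1=O`: > 300000 nM
compound 2 `CCOC(OCC)c1cn(C2C[C@H](O)[C@@H](CO)O2)c(=O)[nH]c1=O`: > 300000 nM
compound 3 `CC(=O)OC[C@H]1OC(n2cc(C3OCCO3)c(=O)[nH]c2=O)C[C@@H]1OC(C)=O`: > 300000 nM

All three were examined in a functional assay on HFF cells (Homo sapiens) for cytotoxicity, read by neutral red uptake; a lower number here means that less compound is tolerated, a higher number that more compound is tolerated. Compound 1 reaches only a limit of the assay at > 300000 nM. Compound 2 likewise gives only a limit, > 300000 nM. Compound 3 also stops at a limit, > 300000 nM. Going by the values given here, the one change that joins two measured compounds, (1,3-dioxolan-2-yl in place of diethoxymethyl on an aromatic carbon), gives the step that the two limits leave unreadable from compound 1 to compound 3; nothing more can be read from it, since (the limit of > 300000 nM in this assay, at which 3 of the 3 values shown sit).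

Compound 4 `O=c1[nH]c(=O)n(C2C[C@H](O)[C@@H](CO)O2)cc1C1OCCO1` has not yet been measured. It stands to compound 2 as compound 3 stands to compound 1: the change is 1,3-dioxolan-2-yl in place of diethoxymethyl on an aromatic carbon. How the core of compound 2 differs from the core of compound 1 is not broken down here. Around the place of the change the two descriptions are not identical in wording: in compound 1 the carbon is meta to a large group, in compound 2 it is meta to a group of 8 heavy atoms, so the change is the same kind of change rather than the same one.

Given that compound 2 sits at > 300000 nM and that compound 1 and compound 3 both remain at the limit, the step is expected to be a step that the limit leaves unreadable from compound 2 to compound 4, meaning compound 4 is estimated at 400000 nM, most probably again reported only as a limit, with a range from 150000 nM to 1000000 nM.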

Compound 4, half-maximal cytotoxic concentration: > 300000 nM
Compound 4 was reported as a limit; the forecaster's own chance of this, stated with the estimate: 85%; the middle value lies beyond the limit too.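

No new step can be read from compound 2 to compound 4, and the pair adds nothing in size to what compound 1 and compound 3 showed, because both ends are limits: the limit of > 300000 nM in this assay, at which 4 of the 4 values shown sit.

The compounds shown leave open whether diethoxymethyl and 1,3-dioxolan-2-yl differ at all in how much compound the cells tolerate, and at what concentration any of the four becomes cytotoxic.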